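Working notes: ethoxycarbonyl to acetamido in the series

The source may report more compounds than this note shows. Statements on the series, on what has been measured and on what is new or still open speak of the compounds shown alone.

Measured in an ADME assay on CHO-K1 cells (Cricetulus griseus) for cytotoxicity, read by MTT assay, with a stated time of 24 h; a higher number here means that more compound is tolerated, a lower number that less compound is tolerated:
- compound 1 `O=C(c1ccccc1)c1ccc(NC(=S)Nc2ccc3[nH]ccc3c2)cc1` gives 20000 nM
- compound 2 `CCOC(=O)c1ccc(NC(=S)Nc2ccc3[nH]ccc3c2)cc1` gives 123000 nM

Of these two, compound 2 stands highest at 123000 nM. The next structure is compound 3 `CC(=O)Nc1ccc(NC(=S)Nc2ccc3[nH]ccc3c2)cc1`, which differs by acetamido in place of ethoxycarbonyl on an aromatic carbon. Among the measured compounds shown here, one measured step bears on this change, a 6.2-fold higher number from compound 1 to compound 2 (0.79 log units; beyond the scatter), a modest step at the same substituent. For the measured compounds named here, no acetamido compound has been measured, so the direction is uncertain. With compound 2 at 123000 nM as the top of the series, a modest drop in this assay is expected. The expected change is a 2.1-fold lower number from compound 2 to compound 3 (0.31 log units; beyond the scatter). Compound 3 is estimated at 60000 nM, with an expected range of 15000 nM to 200000 nM.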

Compound 3, concentration lethal to 50% of the cells: 1040000 nM
For compound 3 the middle estimate is 17-fold (1.24 log units) below the measured one, and the stated range ends below it.
By their numbers in this assay, from the lowest: compound 1; then compound 2; then compound 3.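

In this assay, the earlier pair changed only the group on a carbonyl carbon, whereas this change replaces the whole group on the aromatic carbon, para to a large group, with acetamido, which carries a hydrogen-bond donor. The number rises with an 8.5-fold higher number from compound 2 to compound 3 (0.93 log units; beyond the scatter) and with a 52-fold higher number from compound 1 to compound 3 (1.72 log units; beyond the scatter), leaving compound 3 highest of the three. No measurement shown accounts for this rise.

The compounds shown leave open whether the amide hydrogen matters or acetamido as a whole. A free amine, a carboxylic acid or a longer acyl chain at this position would help separate these readings.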